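A few compounds are considered here, and "the series" means these few. Any claim that something is new, unique, unknown or untested is made for them only; others in the source may bear on it.

Measured compounds in this series:

- compound 1, `CC[C@H](CCCc1cccnc1)NC(=O)/C=C/C=C(c1ccc(OC)cc1)c1ccc(OC)cc1`: 120 nM
- compound 2, `O=C(/C=C/C=C(c1ccc(F)cc1)c1ccc(F)cc1)NCCCCc1cccnc1`: 40 nM
- compound 3, `COc1ccc(C(=C/C=C/C(=O)N[C@@H](CCCc2cccnc2)C2CC2)c2ccc(OC)cc2)cc1`: 60 nM

In an assay (Canis lupus familiaris) for binding affinity to platelet-activating factor receptor (Homo sapiens), read by radioligand binding (a higher number here means a weaker inhibitor, a lower number a stronger inhibitor), compound 3 gives 60 nM, the second highest of the three numbers. Its nearest neighbour is compound 2 at 40 nM, a gap within the scatter; the furthest is compound 1 at 120 nM, also within the scatter. The three numbers therefore sit close together and no ranking among them is secure.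

Compound 4, `COc1ccc(C(=C/C=C/C(=O)NCCCCc2cccnc2)c2ccc(OC)cc2)cc1`, is not yet measured. It differs from compound 3 by hydrogen in place of cyclopropyl on a saturated chain carbon bound to an amide-type nitrogen and a saturated chain carbon.

Among the compounds with values here, one measured step touches the same chain carbon: a 2.0-fold lower number from compound 1 to compound 3 (0.30 log units; within the scatter). Exchanging ethyl for cyclopropyl there left this assay essentially unchanged. Within the data shown here, that step does not remove the substituent altogether, so it is only an indirect guide, and no measured pair isolates the loss of a group at this place. Compound 2 carries a plain chain, but it differs from compound 4 in more than one place, so its value speaks only loosely; it does show that a plain chain is compatible with a number in the same band.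

On that basis no step beyond the scatter is expected from compound 3 to compound 4, and the estimated shift no change at the digits printed from compound 3 to compound 4 (within the scatter) is small. Compound 4 is estimated at 60 nM, with a likely range from 25 nM to 150 nM.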

Compound 4, half-maximal inhibitory concentration: 25 nM
Compound 4: middle estimate off by 2.4-fold (0.38 log units), on the high side; measured number inside the range.
By their numbers in this assay, from the lowest: compounds 4, 2, 3 and 1 (each within the scatter of the next, the first and the last beyond it).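

Working notes on the chain carbon bound to an amide-type nitrogen and a saturated chain carbon: in this assay, hydrogen in place of cyclopropyl gives a 2.4-fold lower number from compound 3 to compound 4 (0.38 log units; beyond the scatter), which shows what the exchange of one substituent for another could not, that removing the group itself moves the number beyond the scatter. Hydrogen in place of ethyl points the same way, with a 4.8-fold lower number from compound 1 to compound 4 (0.68 log units; beyond the scatter), so in this set of compounds sharing the same core, both substituted compounds carry higher numbers than the compound with the plain chain, and neither substituent is needed for a number in this range. Ethyl and cyclopropyl remain within the scatter of each other, so the data separate a substituent from hydrogen at this carbon but do not separate these two groups.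

From the compounds shown here alone, whether methyl, a longer chain or an amine at this carbon, or the opposite arrangement of the substituent there, would follow the same direction remains open. The data at hand offer no explanation for the steps seen at this carbon.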